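The compounds below may be only part of what the source reports. "The series", "measured", "known", "first", "only" and "open" are said of these compounds alone.

Measured so far in this series:

compound 1, `Nc1nc(Cl)c2ncn(Cc3ccccc3CCl)c2n1`: 4470 nM
compound 2, `ClCc1cccc(Cn2cnc3nc(Cl)nc(Cl)c32)c1`: 1410 nM

Both numbers come from a functional assay on K562 cells (Homo sapiens) for cytotoxicity, read by sulforhodamine B assay, with a stated time of 48 h; a lower number here means a stronger inhibitor of growth, a higher number a weaker inhibitor of growth. Compound 1 gives 4470 nM, the highest of the two numbers recorded. Its nearest neighbour is compound 2, which gives 1410 nM, a lower number, and the difference separating the two lies beyond the scatter. The two compounds differ in more than one place, so no single structural step can be read from this pair.

Compound 3, `ClCc1ccccc1Cn1cnc2c(Cl)ncnc21`, remains to be measured in this assay. It differs from compound 1 in one place only: hydrogen in place of amino on an aromatic carbon. Among the compounds with values here, no measured pair in this set isolates such a change, so there is no direct precedent for its size or direction. The step from compound 1 to compound 3 is expected to stay small, most likely within the scatter or only just beyond it, with a slight lean toward a lower number, and the expected step is a 1.5-fold lower number from compound 1 to compound 3 (0.17 log units; within the scatter). For compound 3 a value of 3000 nM is therefore estimated, with a range from 1000 nM to 9000 nM.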

Compound 3, concentration for 50% growth inhibition: 1200 nM
The estimate for compound 3 lay 2.5-fold (0.40 log units) above the measured number; the range from low to high includes it.
By their numbers in this assay, from the lowest: compounds 3 and 2 (each within the scatter of the next); then compound 1.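

Hydrogen in place of amino on an aromatic carbon, between two ring nitrogen atoms, gives a 3.7-fold lower number from compound 1 to compound 3 (0.57 log units; beyond the scatter) in this assay. Within the data shown here, this is the first step that can be read at a single place, and it shows that this position is not indifferent to the change: the direction is toward stronger growth inhibition, and the amino group is not needed for activity, since compound 3 gives 1200 nM without it. No measurement shown here bears on why the number falls.

With only amino and hydrogen compared at this carbon, the compounds shown cannot separate a specific penalty from the amino group from a more general effect of any substituent there, and a methylamino group, a methoxy group or a fluoro group on the same carbon would help to tell these apart. From the compounds shown here alone, it also remains open whether the step carries over to compounds with the chloromethyl group placed differently, or with the chloro group on the six-membered aromatic ring replaced by another group.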